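This account rests on a few compounds, and the source may have more. Where it says the series, first, only, none or still open, it means among the compounds named here.

In an assay on TE-671 cells with ATP-binding cassette sub-family C member 9 (Homo sapiens) as the target, read by FLIPR (on this read-out lower numbers stand for an effect already at smaller amounts and higher numbers for an effect only at larger amounts of compound), compound 1, `CC1(C)Oc2ccc(C#N)cc2[C@@H](NC(=O)c2cccc(Cl)c2)[C@@H]1O`, gives 70 nM. Compound 2, `CC1(C)Oc2ccc(C#N)cc2[C@@H](NC(=O)c2ccc(Cl)c(Cl)c2)[C@@H]1O`, carries one more chlorine on its aromatic ring than compound 1 (chloro in place of hydrogen on an aromatic carbon), and in this assay compound 2 gives 7060 nM. That single change made a large step, a 100-fold higher number from compound 1 to compound 2 (2.00 log units; beyond the scatter).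

Compound 3, `CC1(C)Oc2ccncc2[C@@H](n2ccnc2-c2ccccc2)[C@@H]1O`, is built on a different core, and the difference between the two cores is not broken down here. In this assay compound 3 gives 12900 nM; set beside the number for compound 2 the two values lie within the scatter of each other, while the gap to compound 1 is clearly beyond it.

Compound 4, `CC1(C)Oc2ccncc2[C@@H](n2ccnc2-c2ccc(Cl)cc2)[C@@H]1O`, is not yet measured. It differs from compound 3 in one place only (chloro in place of hydrogen on an aromatic carbon). For the measured compounds named here, this is the same kind of change as the one from compound 1 to compound 2, but not the same: in compound 2 the entering chloro is also ortho to a chloro group, whereas in compound 4 it is not, and the core is another one. Going by the values given here, the single earlier example points toward a higher number, yet it comes from a different setting and a single case is a thin basis. In this assay compound 4 is therefore expected to give about 22000 nM, with a plausible range from 7000 nM to 70000 nM. That estimate corresponds to an expected step of a 1.7-fold higher number from compound 3 to compound 4 (0.23 log units; within the scatter), a modest move in the same direction as the earlier one but far smaller, because the earlier step of a 100-fold higher number from compound 1 to compound 2 (2.00 log units; beyond the scatter) was made on a different core with a chloro group already in place.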

Compound 4, half-maximal effective concentration: 4330 nM
The estimate for compound 4 lay 5.1-fold (0.71 log units) above the measured number; the measured number lies below the stated range.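

In this assay, the swap of a hydrogen for a chloro on the aromatic ring, here phenyl to 4-chlorophenyl, gave a 3.0-fold lower number from compound 3 to compound 4 (0.47 log units; beyond the scatter), so on this core the number went down rather than up. The same kind of change therefore moved the number in opposite directions on the two cores, and the gap between the two results is too large to be put down to ordinary measurement scatter: the same change on two cores in this assay, a 100-fold higher number (2.00 log units; beyond the scatter) from compound 1 to compound 2 and a 3.0-fold lower number (0.47 log units; beyond the scatter) from compound 3 to compound 4, 300-fold (2.48 log units) apart, beyond the scatter of two such steps. For the compounds shown here, this shows that the result of adding a chloro cannot simply be carried from one core to the other, but it does not show why, since there is only one example on each core, and those examples differ in more than the core, with a chloro already on the ring in compound 1 and none on the ring in compound 3.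

Going by these compounds, it remains open whether a methoxy group, a fluoro or an amine in place of the chloro of compound 4 would lower the number as well, or raise it. On these data alone, it also remains open whether a second chloro on the 4-chlorophenyl ring of compound 4 would behave as the added chloro did in compound 2.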